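The compounds below may be only part of what the source reports. "The series", "measured", "known", "first", "only" and "open" are said of these compounds alone.

Measured so far:
- compound 1, `CC1CC/C(=N\Nc2ccc(Br)cc2)c2ncc(C(=O)O)c(=O)n21`: > 1000 umol/kg
- compound 2, `Cc1cccc(N/N=C2\CCC(C)n3c2ncc(C(=O)O)c3=O)c1`: 72.5 umol/kg

Compound 1 stands at the edge of what is shown: in a functional assay on the whole organism for inhibition, with Rattus norvegicus as the target (on this read-out lower numbers stand for an effect already at smaller amounts and higher numbers for an effect only at larger amounts of compound), compound 1 gives only a limit, > 1000 umol/kg, and no number, so it is known only that its value lies at the limit and not where beyond it (the limit of > 1000 umol/kg in this assay, at which 1 of the 2 values shown sits). In the same assay compound 2 gives 72.5 umol/kg, a number rather than a limit. Among the measured compounds shown here, the one measured step, an at least 13-fold lower number from compound 1 to compound 2 (1.13 log units; beyond the scatter), replaces the whole aryl substitution pattern at once and is large.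

Compound 3, `CCCCc1ccc(N/N=C2\CCC(C)n3c2ncc(C(=O)O)c3=O)cc1`, has not yet been measured in this assay. It differs from compound 1 by butyl in place of bromo on an aromatic carbon; the place is on the six-membered aromatic ring of carbon only, para to a large group. This is not the same change as the measured step, which moved from 4-bromophenyl to 3-methylphenyl, so that step bears on it only in showing that a change at the aryl group can move the number far from the limit of compound 1. For compound 3 a step downward is therefore expected, an at least 2.5-fold lower number from compound 1 to compound 3 (0.39 log units; beyond the scatter), though with little support. The estimate for compound 3 in this assay is 400 umol/kg, within 80 umol/kg to 2000 umol/kg, with a real chance that only a limit is again reported.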

Compound 3, dose for 50% inhibition: 100 umol/kg
The estimate for compound 3 lay 4.0-fold (0.60 log units) above the measured number; measured number inside the range.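

At the aromatic carbon para to a large group, butyl in place of bromo gives an at least 10-fold lower number from compound 1 to compound 3 (1.00 log units; beyond the scatter) in this assay. Unlike the earlier step, which altered the whole aryl substitution pattern, this change stays at a single place, so it shows that replacing bromo there is enough on its own to bring a number within the measured range, with the rest of compound 1 left as it is. The value of compound 1 is a limit and not a number, so the step gives only a minimum size: the limit of > 1000 umol/kg in this assay, at which 1 of the 3 values shown sits.

Open, from the compounds shown here alone, is whether the effect depends on the butyl chain itself or would follow from other replacements of bromo at this place, such as hydrogen, chlorine, an amine or a methoxy group, and whether a shorter chain such as ethyl or a longer chain such as hexyl would shift the number further. Also open, going by these compounds, is whether the same replacement would carry over to a core in which the carboxylic acid gives way to an ester or an amide.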